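The source may hold more compounds than are shown below. What is called first, only, known or untested is meant among the compounds shown, and "the series" means these compounds.

Compound 1: `Cn1c(=O)c(=O)n(C2CCCC2)c2nc(N/N=C/c3ccc(S(C)(=O)=O)cc3)ncc21` — 84500 nM
Compound 2: `Cn1c(=O)c(=O)n(C2CCCC2)c2nc(N/N=C/c3ccc(F)cc3Cl)ncc21` — 11000 nM

These two compounds share one core and differ only in the aromatic group attached to the carbon with a double bond to nitrogen. In a functional assay on A549 cells (Homo sapiens) for antiproliferative activity, read by MTT assay (on this read-out lower numbers stand for stronger inhibition and higher numbers for weaker inhibition), compound 1 gives the higher of the two numbers; the nearest comparison is a 7.7-fold lower number from compound 1 to compound 2 (0.89 log units; beyond the scatter), so compound 2 is the stronger inhibitor of the pair.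

Compound 3, `Cn1c(=O)c(=O)n(C2CCCC2)c2nc(N/N=C/c3cccc(O)c3)ncc21`, has not yet been measured. It is reached from compound 1 by this change: 3-hydroxyphenyl in place of 4-(methylsulfonyl)phenyl on a carbon with a double bond to nitrogen. The aromatic ring is kept, but the methylsulfonyl group leaves and a hydroxyl group enters at a different position of the ring.

Within the data shown here, only one measured step bears on this change, the one from compound 1 to compound 2. There, exchanging the 4-(methylsulfonyl)phenyl group for another substituted phenyl gave a modest drop in number. That step involved a different incoming group, so it is an imperfect guide, but it suggests that moving away from 4-(methylsulfonyl)phenyl tends to lower the number. Compound 3 is therefore expected to give about 30000 nM, within a range of 8000 nM to 100000 nM, which would mean an expected step of a 2.8-fold lower number from compound 1 to compound 3 (0.45 log units; beyond the scatter).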

Compound 3, half-maximal inhibitory concentration: > 100000 nM
Compound 3: only a limit was reported (the forecaster's own chance of this, stated with the estimate: 10%); middle value at least 3.3-fold (0.52 log units) away from the limit.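

In this assay, compound 3 gives no number, only a limit of the assay: the limit of > 100000 nM in this assay, at which 1 of the 3 values shown sits. Measured from the stronger compound, the change is clear, with an at least 9.0-fold higher number from compound 2 to compound 3 (0.95 log units; beyond the scatter), so 3-hydroxyphenyl on this carbon with a double bond to nitrogen does not keep the lower number seen with 2-chloro-4-fluorophenyl. Measured from the weaker compound, the limit gives only a floor, an at least 1.1-fold higher number from compound 1 to compound 3 (0.07 log units; that floor lies within the scatter), so 3-hydroxyphenyl and 4-(methylsulfonyl)phenyl cannot be put in order, and replacing 4-(methylsulfonyl)phenyl does not reliably lower the number: compound 2 shows a lower number, while compound 3 does not.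

From the compounds shown here alone, these compounds do not separate the contribution of the hydroxyl group from that of its place on the ring, and how far the true value of compound 3 lies past its limit remains unknown. They also leave open how a phenyl ring carrying an amine or a carboxylic acid, or a phenyl ring with no substituent at all, would read in this assay.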